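This account rests on a few compounds, and the source may have more. Where it says the series, first, only, none or still open, it means among the compounds named here.

Measured compounds in the series:

compound 1 `O=S(=O)(NCCCNCc1ccccc1Cl)c1cc(C(F)(F)F)cc(C(F)(F)F)c1` — in a functional assay on MCF7 cells (Homo sapiens) for inhibition, read by MTT assay, with a stated time of 72 h (on this read-out lower numbers stand for stronger inhibition of growth and higher numbers for weaker inhibition of growth), compound 1 gives 8800 nM
compound 2 `CN(CCCNS(=O)(=O)c1cc(C(F)(F)F)cc(C(F)(F)F)c1)Cc1ccccc1` — in this assay compound 2 gives 16000 nM
compound 3 `O=S(=O)(NCCCNCc1ccc(Br)cc1)c1cc(C(F)(F)F)cc(C(F)(F)F)c1` — in this assay compound 3 gives 1900 nM

Compound 3 holds the lowest number of the three, with a 4.6-fold lower number from compound 1 to compound 3 (0.67 log units; beyond the scatter) and an 8.4-fold lower number from compound 2 to compound 3 (0.93 log units; beyond the scatter) both beyond the scatter, while a 1.8-fold higher number from compound 1 to compound 2 (0.26 log units; within the scatter) stays within it. Compound 4 `COc1ccc(CNCCCNS(=O)(=O)c2cc(C(F)(F)F)cc(C(F)(F)F)c2)cc1` is not yet measured. It differs from compound 3 by methoxy in place of bromo on an aromatic carbon. Within the data shown here, no measured step swaps bromo for methoxy; the only changes on that ring are the two leading to compound 3, which moved a halogen and turned a modest gain. Those steps give no direct reading for a methoxy in the same place, so the estimate leans toward a small loss rather than a further gain, with wide uncertainty. In this assay compound 4 is expected to give 4000 nM, range 1500 nM to 12000 nM, which corresponds to an expected 2.1-fold higher number from compound 3 to compound 4 (0.32 log units; beyond the scatter).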

Compound 4, concentration for 50% growth inhibition: 2500 nM
For compound 4 the middle estimate is 1.6-fold (0.20 log units) above the measured one; measured number inside the range.
By their numbers in this assay, from the lowest: compounds 3 and 4 (each within the scatter of the next); then compounds 1 and 2 (each within the scatter of the next).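

In this assay, methoxy in place of bromo on the aromatic carbon para to a large group gives a 1.3-fold higher number from compound 3 to compound 4 (0.12 log units; within the scatter) and so stays within the scatter, which shows that this place accepts either group with no readable difference. A halogen is therefore not needed here for the lower numbers of this pair, since the methoxy compound also holds a 6.4-fold lower number from compound 2 to compound 4 (0.81 log units; beyond the scatter) and a 3.5-fold lower number from compound 1 to compound 4 (0.55 log units; beyond the scatter) as steps beyond the scatter. No measured evidence bears on why bromo and methoxy read alike at this place.

The compounds shown leave open how a nitrile or a carboxylic acid would read on that aromatic carbon. They also leave open how the plain benzylamino group would read, since compound 2 combines an unsubstituted ring with a methyl on the amine nitrogen.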